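The source may report more compounds than this note shows. Statements on the series, on what has been measured and on what is new or still open speak of the compounds shown alone.

The measured compounds:

Compound 1 `Nc1cccc2c(-c3cccc(NC(=O)c4ccc(Cl)c(C(F)(F)F)c4)c3)ccnc12` gives 3300 nM.
Compound 2 `CC(=O)Nc1cccc2c(-c3cccc(NC(=O)c4ccc(Cl)c(C(F)(F)F)c4)c3)ccnc12` gives 3300 nM.
Compound 3 `Nc1cccc2c(-c3cccc(NC(=O)Nc4cc(C(F)(F)F)cc(C(F)(F)F)c4)c3)ccnc12` gives 2100 nM.

All three numbers come from a functional assay on M14 cells (Homo sapiens) for antiproliferative activity, read by sulforhodamine B assay, with a stated time of 48 h; on this read-out higher numbers stand for weaker inhibition and lower numbers for stronger inhibition. Compound 1 and compound 2 share one core, and compound 3 carries a different one; the difference between the two cores is not broken down here. Compound 3 sits at the lowest of the three numbers, but its gaps to compound 1 and to compound 2 both lie within the scatter, so no order among the three is claimed.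

The change from compound 1 to compound 2 is acetyl in place of hydrogen on a nitrogen on an aromatic ring. On this pair the step is no change at the digits printed from compound 1 to compound 2 (within the scatter).

Compound 4 `CC(=O)Nc1cccc2c(-c3cccc(NC(=O)Nc4cc(C(F)(F)F)cc(C(F)(F)F)c4)c3)ccnc12` has not yet been measured in this assay. It stands to compound 3 as compound 2 stands to compound 1: the difference is acetyl in place of hydrogen on a nitrogen on an aromatic ring. The two descriptions of the place are the same word for word, so this is the same change on a different core.

The expectation for compound 4 rests on compound 1 and compound 2, where the same change gave no change at the digits printed from compound 1 to compound 2 (within the scatter). Compound 4 is therefore expected to show a step of about no change at the digits printed from compound 3 to compound 4 (within the scatter) from compound 3, that is, no movement beyond the scatter. Compound 4 is estimated at 2100 nM, with a range from 1000 nM to 4400 nM.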

Compound 4, half-maximal inhibitory concentration: 14200 nM
Beside the measured number, compound 4's estimate is 6.8-fold (0.83 log units) below it, and the stated range ends below it.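

In this assay, acetyl in place of hydrogen on a nitrogen on an aromatic ring gives a 6.8-fold higher number from compound 3 to compound 4 (0.83 log units; beyond the scatter), so on the core of compound 3 the change moves the number beyond the scatter. Among these compounds, the same change therefore did not carry over from the core of compound 1 to the core of compound 3 with the same outcome, and the two steps differ: the same change on two cores in this assay, no change at the digits printed (within the scatter) from compound 1 to compound 2 and a 6.8-fold higher number (0.83 log units; beyond the scatter) from compound 3 to compound 4, 6.8-fold (0.83 log units) apart, beyond the scatter of two such steps This shows only that the step depends on the core in these two matched pairs; it does not show which feature of the cores matters, since they differ in more than one place, and two pairs cannot give a rule for any further core.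

The compounds shown leave open whether a methyl, a propionyl or a methanesulfonyl group on that same nitrogen would follow the step seen with compound 2 or the one seen with compound 4. They also leave open whether keeping one part of the core of compound 3 and exchanging the other, for instance replacing a trifluoromethyl group with a chlorine atom, would be enough to bring the step from the acetamido group back within the scatter.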